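A Fluorophenyl Ether on a Shared Diamino Core

The source may report more compounds than this note shows. Statements on the series, on what has been measured and on what is new or still open speak of the compounds shown alone.

Compound 1 `Nc1cc(N)c2nc(-c3ccccc3)c(Oc3ccc(Cl)c(Cl)c3)nc2c1` in a functional assay on OVCAR-5 cells (Homo sapiens) for inhibition, read by sulforhodamine B assay, with a stated time of 48 h (on this read-out lower numbers stand for higher toxicity in this test and higher numbers for lower toxicity in this test), gives only a limit, < 100000 nM.
Compound 2 `Nc1cc(N)c2nc(-c3ccccc3)c(NCc3ccc(Cl)c(Cl)c3)nc2c1` in this assay gives 69200 nM.
Compound 3 `CCOC(=O)[C@H](CCC(=O)O)NC(=O)c1ccc(Sc2nc3cc(N)cc(N)c3nc2-c2ccccc2)cc1` in this assay gives only a limit, < 100000 nM.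

Compound 1 thus stands at the edge of what this assay can report, at the limit of < 100000 nM in this assay, at which 2 of the 3 values shown sit. Only compound 2 yields an actual number, and that number is itself weak. Compound 4 `Nc1cc(N)c2nc(-c3ccccc3)c(Oc3ccc(F)cc3)nc2c1` differs from compound 1 in a single place: 4-fluorophenyl in place of 3,4-dichlorophenyl on an oxygen on an aromatic ring. Going by the values given here, no step between two measured compounds is known here, so there is no measured guide to the size or direction of this change; the step that the limit leaves unreadable from compound 1 to compound 4 is expected to be small, with no direction beyond the usual scatter. Compound 4 is therefore estimated at 70000 nM, with a likely range from 30000 nM to 150000 nM.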

Compound 4, concentration lethal to 50% of the cells: < 100000 nM
Compound 4 gave a limit, no number; the forecaster's own chance of this, stated with the estimate: 50%; the middle value does not contradict the limit.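

Going by these compounds alone, compound 1 and compound 4 each give only a limit, so no step between them can be read: the limit of < 100000 nM in this assay, at which 3 of the 4 values shown sit.

On these data alone, whether 4-fluorophenyl and 3,4-dichlorophenyl on the shared core differ at all in this assay stays open.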